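Cytotoxicity notes on the benzimidazole-free description: acetyl for nitro

The source may report more compounds than this note shows. Statements on the series, on what has been measured and on what is new or still open speak of the compounds shown alone.

The series is followed in an ADME assay on MT4 cells (Homo sapiens) for cytotoxicity, read by MTT assay, with a stated time of 96 h; on this read-out higher numbers stand for lower toxicity in this test and lower numbers for higher toxicity in this test. Compound 1, `COc1ccc(-c2nc3cc(C(C)=O)ccc3[nH]2)c(OC)c1OC`, is measured only as a limit of the assay and returns > 100000 nM. Compound 2, `O=C(CN1CCCC1)Nc1ccc(-c2nc3cc(C(F)(F)F)ccc3[nH]2)cc1`, gives a number, 18000 nM. Compound 3, `COc1ccc(-c2nc3cc([N+](=O)[O-])ccc3[nH]2)c(OC)c1`, is likewise recorded only as a limit of the assay, > 100000 nM. Among the measured compounds shown here, compound 3 thus sits at the limit of > 100000 nM in this assay, at which 2 of the 3 values shown sit, together with compound 1, while compound 2 is the single compound of the set with a numerical read-out.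

Compound 4, `COc1ccc(-c2nc3cc(C(C)=O)ccc3[nH]2)c(OC)c1`, is not yet measured. Its difference from compound 3 is acetyl in place of nitro on an aromatic carbon.

For the measured compounds named here, no step between measured compounds is recorded, so no measured size is available for this change. The nearest comparison is compound 1, which carries the same acetyl group and stands at > 100000 nM; on that basis the step from compound 3 to compound 4 is expected to be none beyond the scatter, a number no higher from compound 3 to compound 4 (the limit leaves the size open), most likely again reported as a limit. Compound 4 is estimated at 100000 nM, within 50000 nM to 200000 nM.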

Compound 4, half-maximal cytotoxic concentration: > 100000 nM
Compound 4 gave a limit, no number (the forecaster's own chance of this, stated with the estimate: 70%); the middle value lies on the limit itself.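

Compound 4 stands with compound 1 and compound 3 at a limit, not a number, so the steps linking compound 4 to compound 3 and to compound 1 cannot be read: the limit of > 100000 nM in this assay, at which 3 of the 4 values shown sit. Going by these compounds, whether acetyl in place of nitro, or hydrogen in place of methoxy, shifts this read-out at all stays open.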